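Pyrrolidin-1-yl for Morpholin-4-yl on a Thiocarbonyl Carbon

A few compounds are considered here, and "the series" means these few. Any claim that something is new, unique, unknown or untested is made for them only; others in the source may bear on it.

Measured so far:
compound 1, `N/C(=N\NC(=S)N1CCOCC1)c1ccc(F)cn1`, 4000 nM
compound 2, `N/C(=N\NC(=S)N1CCCCC1)c1ccccn1`, 6900 nM

Both numbers come from a functional assay on A-431 cells (Homo sapiens) for cytotoxicity, read by MTT assay, with a stated time of 72 h; on this read-out higher numbers stand for weaker inhibition and lower numbers for stronger inhibition. Compound 1 gives the lower of the two numbers, with compound 2 the nearest, but the gap between them is within the usual scatter of repeated measurements, so the two compounds cannot be ranked against each other on this evidence.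

Compound 3 is `N/C(=N\NC(=S)N1CCCC1)c1ccc(F)cn1` and has not yet been measured in this assay. It differs from compound 1 in one place: pyrrolidin-1-yl in place of morpholin-4-yl on a thiocarbonyl carbon. Compound 2 also carries a ring without an oxygen on the thiocarbonyl carbon, yet it differs from compound 1 in a second place as well, so it cannot show what this single change does.

For the measured compounds named here, with no measured pair that isolates this change, there is no basis to expect a step beyond the scatter in either direction. The expected step from compound 1 to compound 3 is a 1.1-fold higher number from compound 1 to compound 3 (0.05 log units; within the scatter). Compound 3 is therefore estimated at 4500 nM, in a range from 1500 nM to 13000 nM.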

Compound 3, half-maximal inhibitory concentration: 1000 nM
Estimate against measurement, compound 3: 4.5-fold (0.65 log units) above, outside the stated range (below it).
By their numbers in this assay, from the lowest: compound 3; then compounds 1 and 2 (each within the scatter of the next).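

In this assay, putting pyrrolidin-1-yl in place of morpholin-4-yl on a thiocarbonyl carbon gives a 4.0-fold lower number from compound 1 to compound 3 (0.60 log units; beyond the scatter), a modest step but one beyond the scatter, and on this read-out the lower number means stronger inhibition. The earlier compounds shown here could not show this, as they differed in more than one place; this pair shows that the group on the thiocarbonyl carbon can change the cell result while the rest of the molecule stays the same. The swap alters two things together, removing the ring oxygen and shrinking a six-membered ring to a five-membered one, so this single step cannot separate the two, and nothing available explains why the number falls.

The compounds shown leave open whether ring size or the oxygen matters more: azetidin-1-yl would extend the series to a smaller ring, while thiomorpholin-4-yl would keep the six-membered ring and put sulfur where the oxygen stands. On these data alone, it also remains open whether the same swap would give a similar step on a core without the fluorine.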